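The source may hold more compounds than are shown below. What is called first, only, known or untested is meant among the compounds shown, and "the series" means these compounds.

Measured so far in a functional assay on HeLa cells (Homo sapiens) for inhibition, read by CCK-8 assay, with a stated time of 48 h; on this read-out lower numbers stand for stronger inhibition and higher numbers for weaker inhibition:
compound 1 `COc1cc(-c2ccnc3cc(-c4ccc(Cl)cc4)nn23)cc(OC)c1OC` — 1490 nM
compound 2 `COc1cc(-c2ccnc3cc(-c4ccc(C(C)(C)C)cc4)nn23)cc(OC)c1OC` — a limit of the assay, > 10000 nM
compound 3 `COc1cc(-c2ccnc3cc(-c4c[nH]c5ccccc45)nn23)cc(OC)c1OC` — 195 nM

Compound 3 holds the lowest number of the two numbers shown; its nearest neighbour is compound 1, with a 7.6-fold lower number from compound 1 to compound 3 (0.88 log units; beyond the scatter). Compound 2 sits at the limit of > 10000 nM in this assay, at which 1 of the 3 values shown sits, and gives no number, so against it compound 3 shows only an at least 51-fold lower number from compound 2 to compound 3 (1.70 log units; beyond the scatter).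

Compound 4 `COc1cc(-c2ccnc3cc(-c4cn(C(=O)OC(C)(C)C)c5ccccc45)nn23)cc(OC)c1OC` differs from compound 3 by tert-butoxycarbonyl in place of hydrogen on an aromatic nitrogen. Among the measured compounds shown here, no measured step touches the aromatic nitrogen of the fused ring, so none bears on this change directly. For the measured compounds named here, the one step in which a tert-butyl group enters, an at least 6.7-fold higher number from compound 1 to compound 2 (0.82 log units; beyond the scatter), went to a higher number, and the large at least 51-fold lower number from compound 2 to compound 3 (1.70 log units; beyond the scatter) reversed it when the indole replaced that ring. On that indirect footing a step in this assay toward a higher number is expected for compound 4, of a size at least beyond the scatter.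

For compound 4 the estimated value in this assay is 1500 nM, within 400 nM to 8000 nM, which means an expected 7.7-fold higher number from compound 3 to compound 4 (0.89 log units; beyond the scatter).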

Compound 4, half-maximal inhibitory concentration: 3770 nM
Compound 4: the middle estimate sits 2.5-fold (0.40 log units) below what was measured; the range from low to high includes it.
By their numbers in this assay, from the lowest: compound 3; then compound 1; then compound 4. At a limit, above all of these: compound 2.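

In this assay, among the compounds shown here, tert-butoxycarbonyl in place of hydrogen on the aromatic nitrogen gives a 19-fold higher number from compound 3 to compound 4 (1.29 log units; beyond the scatter), the first step here made on the fused ring system itself rather than by exchanging the whole aromatic group on the shared core. The lower number gained with the 1H-indol-3-yl group in a 7.6-fold lower number from compound 1 to compound 3 (0.88 log units; beyond the scatter) is therefore not independent of what sits on this nitrogen: one change at this atom is enough for a large step. Nothing measured here gives a reason for this step.

The compounds shown leave open whether any group on this nitrogen raises the number or whether this follows from tert-butoxycarbonyl alone. A methyl group, an acetyl group or a short chain ending in an amine at the same atom would separate these readings.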